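A few compounds are considered here, and "the series" means these few. Any claim that something is new, unique, unknown or untested is made for them only; others in the source may bear on it.

Values so far in a functional assay on HUVEC cells (Homo sapiens), read by scintillation counting and thymidine incorporation, with a stated time of 24 h; a higher number here means a weaker inhibitor, a lower number a stronger inhibitor

Compound 1 `CCC(C)n1ncn(-c2ccc(N3CCN(c4ccc(OC[C@@H]5CO[C@@](CBr)(c6ccc(Cl)cc6Cl)O5)cc4)CC3)cc2)c1=O` gives 569 nM
Compound 2 `CCC(C)n1ncn(-c2ccc(N3CCN(c4ccc(OC[C@@H]5CO[C@@](Cn6cnc(C)n6)(c6ccc(Cl)cc6Cl)O5)cc4)CC3)cc2)c1=O` gives 272 nM
Compound 3 `CCC(C)n1ncn(-c2ccc(N3CCN(c4ccc(OC[C@@H]5CO[C@@](Cn6nc(C)nc6C)(c6ccc(Cl)cc6Cl)O5)cc4)CC3)cc2)c1=O` gives 221 nM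

Compound 3 and compound 2 cannot be told apart: the gap is a 1.2-fold lower number from compound 2 to compound 3 (0.09 log units; within the scatter) and it comes from methyl in place of hydrogen on an aromatic carbon. Compound 1 stands clearly apart from both, with a 2.6-fold lower number from compound 1 to compound 3 (0.41 log units; beyond the scatter) on swapping bromo for 3,5-dimethyl-1H-1,2,4-triazol-1-yl, and a 2.1-fold lower number from compound 1 to compound 2 (0.32 log units; beyond the scatter) on swapping bromo for 3-methyl-1H-1,2,4-triazol-1-yl.

Compound 4 `CCC(C)n1ncn(-c2ccc(N3CCN(c4ccc(OC[C@@H]5CO[C@@](Cn6cnc(C)c6)(c6ccc(Cl)cc6Cl)O5)cc4)CC3)cc2)c1=O` keeps the shared core and changes one group. The difference is 4-methyl-1H-imidazol-1-yl in place of 3,5-dimethyl-1H-1,2,4-triazol-1-yl on a saturated chain carbon bound to a saturated ring carbon and it amounts to 4-methyl-1H-imidazol-1-yl in place of 3,5-dimethyl-1H-1,2,4-triazol-1-yl on a saturated chain carbon bound to a saturated ring carbon.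

Among the compounds with values here, no measured compound carries this new group, so no step speaks to it directly. The closest guides are the modest steps away from bromo and the methyl change, which stayed within the scatter. On that basis, no step beyond the scatter is expected in this assay for this swap. The estimated step is a 1.1-fold higher number from compound 3 to compound 4 (0.05 log units; within the scatter) and that is only an expectation. Compound 4 is estimated at 250 nM with a range of 110 nM to 560 nM expected for it.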

Compound 4, half-maximal inhibitory concentration: 102 nM
The estimate for compound 4 lay 2.5-fold (0.39 log units) above the measured number, outside the stated range (below it).
By their numbers in this assay, from the lowest: compound 4; then compounds 3 and 2 (each within the scatter of the next); then compound 1.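

In this assay this position, the saturated chain carbon bound to a saturated ring carbon, responds to the identity of the ring itself and not only to the loss of bromo: the imidazole gives a 2.2-fold lower number from compound 3 to compound 4 (0.34 log units; beyond the scatter) and also a 2.7-fold lower number from compound 2 to compound 4 (0.43 log units; beyond the scatter) while the added methyl on the triazole made no difference beyond the scatter. Going from bromo to 4-methyl-1H-imidazol-1-yl gives a 5.6-fold lower number from compound 1 to compound 4 (0.75 log units; beyond the scatter) and is the largest step away from bromo among these compounds. As the group names show, compound 2 and compound 4 each carry one methyl on a five-membered aromatic ring and differ in that ring's hetero atoms, yet nothing available explains why the imidazole gives the lower number.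

On these data alone, it remains open whether the methyl matters on the imidazole, as it did not on the triazole, and plain 1H-imidazol-1-yl would test that directly. Also open, as far as these compounds go, is how this position would respond to a group of a different kind, such as a morpholine ring or a carboxylic acid on the same chain carbon.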